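A Methyl Added to a Series Sitting at the Limit

The compounds below may be only part of what the source reports. "The series", "measured", "known", "first", "only" and "open" are said of these compounds alone.

Three compounds were tested in a toxicity assay on BJ cells (Homo sapiens) for cytotoxicity, read by MTT assay, with a stated time of 24 h; a higher number here means a weaker inhibitor, a lower number a stronger inhibitor. Compound 1 `CCOC(=O)N1CCC(=NNC(=O)c2ccc(Cl)cc2)CC1` gives > 400000 nM, a limit of the assay rather than a number. Compound 2 `CCOC(=O)N1CCC(=NNC(=O)c2ccc([N+](=O)[O-])cc2)CC1` gives > 400000 nM, likewise a limit. The step that the two limits leave unreadable from compound 1 to compound 2 is therefore unreadable. Compound 3 `O=C(NN=C1CC(c2ccccc2)NC(c2ccccc2)C1)c1ccccc1` gives > 400000 nM, again a limit. Among the compounds with values here, as the limit of > 400000 nM in this assay, at which 3 of the 3 values shown sit, records, every value so far sits at that limit, so nothing places compound 3 above or below any other compound. Compound 4 `Cc1ccc(C(=O)NN=C2CC(c3ccccc3)NC(c3ccccc3)C2)cc1` differs from compound 3 by methyl in place of hydrogen on an aromatic carbon. No measured step resembles this change, and the only step shown cannot be read. Compound 4 is therefore expected to remain at the limit, with an estimated step that the limit leaves unreadable from compound 3 to compound 4. The estimate for compound 4 is 500000 nM, within 200000 nM to 2000000 nM.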

Compound 4, half-maximal inhibitory concentration: > 400000 nM
Compound 4 was reported as a limit (the forecaster's own chance of this, stated with the estimate: 90%); the middle value does not contradict the limit.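

The step from compound 3 to compound 4 cannot be read, since both results are limits: the limit of > 400000 nM in this assay, at which 4 of the 4 values shown sit. The compounds shown leave open how strongly, if at all, any of them acts in this assay, and whether methyl changes that.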